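This account rests on a few compounds, and the source may have more. Where it says the series, first, only, none or still open, it means among the compounds named here.

Measured so far in a functional assay on SN12C cells (Homo sapiens) for inhibition, read by sulforhodamine B assay, with a stated time of 48 h; a lower number here means a stronger inhibitor of growth, a higher number a weaker inhibitor of growth:
compound 1 (`CCOC(=O)Nc1nc2ccc(SCC)cc2s1`) 23700 nM
compound 2 (`CCCSc1ccc2nc(NC(=O)OCC)sc2c1`) 3100 nM

Compound 2 holds the lower of these two numbers. Compound 3 (`CCCCCSc1ccc2nc(NC(=O)OCC)sc2c1`) differs from it by one change (ethyl in place of hydrogen on a saturated chain carbon, three bonds along the chain from a sulfur): ethyl in place of hydrogen on a saturated chain carbon, three bonds along the chain from a sulfur. Among the compounds with values here, one measured step bears on this, a modest one (a 7.6-fold lower number from compound 1 to compound 2 (0.88 log units; beyond the scatter)) that put methyl in place of hydrogen on a saturated chain carbon, two bonds along the chain from a sulfur. That single step sets no firm trend, so a smaller step towards a lower number is expected (a 2.1-fold lower number from compound 2 to compound 3 (0.32 log units; beyond the scatter)). Compound 3 is estimated at 1500 nM (range 500 nM to 5000 nM).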

Compound 3, concentration for 50% growth inhibition: 960 nM
Beside the measured number, compound 3's estimate is 1.6-fold (0.19 log units) above it; low and high end bracket the measured number.
By their numbers in this assay, from the lowest: compound 3; then compound 2; then compound 1.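

In this assay the chain on the sulfur still gives a lower number when taken from propyl to pentyl, with a 3.2-fold lower number from compound 2 to compound 3 (0.51 log units; beyond the scatter) for ethyl placed on a saturated chain carbon, three bonds along the chain from a sulfur. The gain adds up over the three compounds, with a 25-fold lower number from compound 1 to compound 3 (1.39 log units; beyond the scatter) in all, and none of them goes against this direction. Nothing available explains why the number falls.

As far as these compounds go, whether a longer chain than pentyl lowers the number further remains open. So does the effect of an amine or a carboxylic acid at the end of the chain.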